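This account rests on a few compounds, and the source may have more. Where it says the series, first, only, none or still open, it means among the compounds named here.

Series notes. Compound 1 `C/C(=N/O)c1ccc(NC(=O)Cn2nc(-c3ccccc3)nc2N)cc1` is the reference point. In a functional assay on U-251 cells (Homo sapiens) for inhibition, read by sulforhodamine B assay, with a stated time of 48 h, tested at 10 uM (on this read-out higher numbers stand for more inhibition of growth at the one concentration tested and lower numbers for less inhibition of growth), compound 1 gives 8.76%, the highest of the two numbers in hand. Among the measured compounds shown here, compound 2 `COc1ccc(-c2nc3sc(-c4ccc(Cl)cc4)cn3n2)cc1` is the only other measured compound; in this assay compound 2 gives -67.9%, a gap beyond the scatter. Compound 3 `C/C(=N/O)c1ccc(NC(=O)Cn2nc(C(F)(F)F)nc2N)cc1` is unmeasured. Its change from compound 1: trifluoromethyl in place of phenyl on an aromatic carbon, the trifluoromethyl sitting between two ring nitrogen atoms. For the measured compounds named here, no measured step informs this change, so nothing beyond the scatter is expected. Compound 3 is estimated at 5%, range -20% to 25%, an expected step of a number 3.8 percentage points lower from compound 1 to compound 3 (within the scatter).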

Compound 3, percent growth inhibition at one concentration: 11.3%
The estimate for compound 3 lay 6.3 percentage points below the measured number; measured number inside the range.
By their numbers in this assay, from the lowest: compound 2; then compounds 1 and 3 (each within the scatter of the next).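

In this assay, among the compounds shown here, trifluoromethyl in place of phenyl on the aromatic carbon between two ring nitrogen atoms gives a number 2.5 percentage points higher from compound 1 to compound 3 (within the scatter) and is the first reading at this position. In this pair, the one six-membered aromatic ring of carbon only can leave this position without a change beyond the scatter, so it is not required to hold the read-out at this level. No measurement at hand bears on why the step is this small. On these data alone, whether an amine or a carboxylic acid on this carbon would move the number beyond the scatter stays open.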